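Swapping Methyl for Diethylamino on the Shared Core

The source may report more compounds than this note shows. Statements on the series, on what has been measured and on what is new or still open speak of the compounds shown alone.

Measured compounds:
compound 1 `Cc1ccc2nc(-c3ccccc3C(F)(F)F)[nH]c(=O)c2c1`: 21.1%
compound 2 `Cc1ccc2nc(-c3ccccc3OC(F)(F)F)[nH]c(=O)c2c1`: 0%
compound 3 `Cc1ccc2nc(-c3ccccc3C)[nH]c(=O)c2c1`: "not determined" (no result reported) in an assay on isolated protein for inhibition of DNA topoisomerase 1 (Homo sapiens), with a stated time of 30 min, tested at 20 uM; a higher number here means a stronger effect of the compound at the concentration tested, a lower number a weaker effect

Compound 1 gives the highest of the two numbers in this assay; compound 2 lies below it, as the step of a number 21.1 percentage points lower from compound 1 to compound 2 (beyond the scatter) shows, a modest change lying beyond the scatter. Compound 4 `CCN(CC)c1ccc2nc(-c3ccccc3C(F)(F)F)[nH]c(=O)c2c1` differs from compound 1 by diethylamino in place of methyl on an aromatic carbon. Among the measured compounds shown here, no measured step touches this place on the core; the only measured step alters the other ring. Without a comparable step, only a small or modest move in either direction can be expected, and compound 4 is therefore estimated at 22%, within 3% to 45%, an expected step of a number 0.9 percentage points higher from compound 1 to compound 4 (within the scatter).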

Compound 4, a percentage reported as inhibition, at one concentration (the size of the read-out at that concentration, not a potency): 13.3%
Beside the measured number, compound 4's estimate is 8.7 percentage points above it; the measured number falls inside the stated range.
By their numbers in this assay, from the lowest: compound 2; then compounds 4 and 1 (each within the scatter of the next).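

At this place on the core, diethylamino brings more heavy atoms than methyl and adds a hydrogen-bond acceptor, yet this assay shows only a number 7.8 percentage points lower from compound 1 to compound 4 (within the scatter). So this exchange gives no read-out distinguishable from that of methyl, although the single step cannot define what this position accepts. No available evidence bears on this result.

As far as these compounds go, whether dimethylamino, a morpholine ring or a carboxylic acid at this place would move the read-out beyond the scatter remains open. So does whether diethylamino would behave alike with the trifluoromethoxy of compound 2 on the other ring.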